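A few compounds are considered here, and "the series" means these few. Any claim that something is new, unique, unknown or untested is made for them only; others in the source may bear on it.

Measured compounds:
compound 1 `CN(c1cccc2c1CN(c1nc(Nc3cc(C(F)(F)F)cc(C(F)(F)F)c3)ncc1C(F)(F)F)C2)S(C)(=O)=O` gives 9200 nM
compound 2 `Cc1cc(Cl)ccc1Nc1ncc(C(F)(F)F)c(N2Cc3cccc(N(C)S(C)(=O)=O)c3C2)n1` gives 17400 nM
compound 3 `CN(c1cccc2c1CN(c1nc(Nc3ccc(Cl)c(C(F)(F)F)c3)ncc1C(F)(F)F)C2)S(C)(=O)=O` gives 11100 nM

In a functional assay on HeLa cells (Homo sapiens) for antiproliferative activity, read by spectrophotometry, with a stated time of 2 days (on this read-out lower numbers stand for stronger inhibition of growth and higher numbers for weaker inhibition of growth), compound 2 has the highest of the three numbers, yet it sits within the scatter of both neighbours: compound 3 lies a 1.6-fold lower number from compound 2 to compound 3 (0.20 log units; within the scatter), and compound 1, the furthest of the three, is likewise within the scatter of compound 2. The three measured compounds therefore cannot be told apart on this read-out.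

Compound 4 `COc1cc(Nc2ncc(C(F)(F)F)c(N3Cc4cccc(N(C)S(C)(=O)=O)c4C3)n2)cc(OC)c1` has not yet been measured in this assay. It differs from compound 2 in one place: 3,5-dimethoxyphenyl in place of 4-chloro-2-methylphenyl on a nitrogen on an aromatic ring. For the measured compounds named here, the only measured step that bears on this change is the one from compound 2 to compound 3, where another group replaced the 4-chloro-2-methylphenyl on the same nitrogen, and that step stayed within the scatter. Going by the values given here, no measured compound carries a 3,5-dimethoxyphenyl, so nothing shows how that group itself behaves. On this basis compound 4 is expected to show no step beyond the scatter, which corresponds to an estimated 1.2-fold lower number from compound 2 to compound 4 (0.09 log units; within the scatter). Compound 4 is thus estimated at 14000 nM, within a range from 5000 nM to 40000 nM.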

Compound 4, concentration for 50% growth inhibition: 7000 nM
The estimate for compound 4 lay 2.0-fold (0.30 log units) above the measured number, within the range that was stated.
By their numbers in this assay, from the lowest: compounds 4, 1, 3 and 2 (each within the scatter of the next, the first and the last beyond it).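

In this assay, the aromatic group on this nitrogen proved able to shift the number beyond the scatter: 3,5-dimethoxyphenyl in place of 4-chloro-2-methylphenyl gave a 2.5-fold lower number from compound 2 to compound 4 (0.40 log units; beyond the scatter), a modest step, whereas the earlier change at this position had stayed within the scatter. The gain does not set 3,5-dimethoxyphenyl apart from every other group at this place, since its replacement of 4-chloro-3-(trifluoromethyl)phenyl gave a 1.6-fold lower number from compound 3 to compound 4 (0.20 log units; within the scatter), which lies within the scatter. Nothing measured here explains the step.

The compounds shown do not reveal whether the step depends on the methoxy groups that enter or on the chlorine and methyl that leave. From the compounds shown here alone, it also remains open how this position would respond to an amine or a carboxylic acid on the phenyl ring.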